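Sulfamoyl in place of fluoro: from compound 1 to compound 3

The source may report more compounds than this note shows. Statements on the series, on what has been measured and on what is new or still open speak of the compounds shown alone.

Measured so far:
compound 1 `Fc1cccc(Nc2nccc(-c3ccccn3)n2)c1`, 1000 nM
compound 2 `CCOC(=O)C(=O)N(c1ccccc1)c1nccc(-c2ccncc2)n1`, 2200 nM

In a functional assay for inhibition, with Homo sapiens as the target (a lower number here means a stronger inhibitor, a higher number a weaker inhibitor), compound 1 gives 1000 nM and compound 2 gives 2200 nM. Compound 1 thus holds the lowest of the two numbers; compound 2 lies higher by a margin beyond the usual scatter. Among the measured compounds shown here, the two differ in more than one place, so no single-point step has been measured.

Compound 3 `NS(=O)(=O)c1cccc(Nc2nccc(-c3ccccn3)n2)c1` differs from compound 1 by sulfamoyl in place of fluoro on an aromatic carbon. For the measured compounds named here, no measured step covers a change of this kind. In this assay a small step is expected, a 1.4-fold lower number from compound 1 to compound 3 (0.15 log units; within the scatter), not clearly beyond the scatter in either direction. Compound 3 is estimated at 700 nM, range 150 nM to 3000 nM.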

Compound 3, half-maximal inhibitory concentration: 500 nM
The estimate for compound 3 lay 1.4-fold (0.15 log units) above the measured number; measured number inside the range.
By their numbers in this assay, from the lowest: compounds 3 and 1 (each within the scatter of the next); then compound 2.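

On an aromatic carbon meta to a large group, sulfamoyl in place of fluoro gives a 2.0-fold lower number from compound 1 to compound 3 (0.30 log units; within the scatter) in this assay. Compound 1 and compound 3 are therefore not separated, so this position accepts a group of four heavy atoms, with a hydrogen-bond donor and acceptors, without a change beyond the scatter. No supporting measurement explains this result.

Open, as far as these compounds go, is whether an amine, a carboxylic acid or a methyl group at this position would also leave the number within the scatter. Also open, from the compounds shown here alone, is whether sulfamoyl behaves the same way on other carbons of this ring.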